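The compounds below may be only part of what the source reports. "The series", "measured", "known", "first", "only" and "open" are said of these compounds alone.

Measured compounds:
compound 1, `CN(C)CCN1CCN(c2nc(-c3ccccn3)nc3c2CN(Cc2ccccc2)CC3)CC1` — 41.3%
compound 2, `CC(C)c1ccc(CN2CCc3nc(-c4ccccn4)nc(N4CCN(CCN(C)C)CC4)c3C2)cc1` — 57.2%
compound 3, `CN(C)CCN1CCN(c2nc(-c3ccccn3)nc3c2CN(CC2CCCCC2)CC3)CC1` — 41%

Compound 3 stands lowest of the three in an assay on FRT cells with Cystic fibrosis transmembrane conductance regulator variant F508del (Homo sapiens) as the target, read by fluorescence, with a stated time of 25 min; on this read-out higher numbers stand for larger maximal responses and lower numbers for smaller maximal responses; compound 1 is its nearest neighbour, within the scatter, and compound 2 its furthest, beyond it. Compound 4, `CN(C)CCN1CCN(c2nc(-c3ccccn3)nc3c2CN(C(=O)c2ccccc2)CC3)CC1`, differs from compound 3 by benzoyl in place of cyclohexylmethyl on an amine nitrogen in a ring. Among the measured compounds shown here, two measured steps touch the same nitrogen: a number 0.3 percentage points lower from compound 1 to compound 3 (within the scatter) and a number 16.2 percentage points lower from compound 2 to compound 3 (beyond the scatter). For the measured compounds named here, the only change beyond the scatter there came with the isopropyl-bearing ring of compound 2; swapping a phenyl for a cyclohexyl left this assay unchanged. With a benzoyl carrying no further substituent, a step of a number 1 percentage points higher from compound 3 to compound 4 (within the scatter) is expected, within the scatter. Compound 4 is therefore estimated at 42%, between 28% and 58%.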

Compound 4, largest response reached (Emax), in percent of the reference or control that the assay uses: "not active" (no number reported)
For compound 4 the study gives words and no number; there is nothing to compare the estimate with.
By their numbers in this assay, from the lowest: compounds 3 and 1 (each within the scatter of the next); then compound 2.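

Among the compounds shown here, compound 4 is reported as not active in this assay, without a number, so no step from compound 3 to compound 4 can be read. The compounds shown leave open how large the change on swapping cyclohexylmethyl for benzoyl really is. Nothing shown bears on this result.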